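This account rests on a few compounds, and the source may have more. Where it says the series, first, only, none or still open, it means among the compounds named here.

Measured in an assay for inhibition of Amine oxidase [flavin-containing] B (Mus musculus), read by fluorescence, with a stated time of 30 min, in the presence of a further agent that is not named here; on this read-out higher numbers stand for weaker inhibition and lower numbers for stronger inhibition:
- compound 1 `Cc1ccc(C(=O)Nc2ccc(-c3nc4c([nH]3)c(=O)n(C)c(=O)n4C)cc2)cc1`: 13900 nM
- compound 2 `COc1ccc(C(=O)Nc2ccc(-c3nc4c([nH]3)c(=O)n(C)c(=O)n4C)cc2)cc1`: 17200 nM
- compound 3 `Cc1ccc(C(=O)Nc2cccc(-c3nc4c(c(=O)n(C)c(=O)n4C)n3C)c2)cc1`: 16700 nM

All three values of this assay lie within the scatter of one another. The difference between the core of compound 1 and the core of compound 3 is not broken down here.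

Compound 2 differs from compound 1 by methoxy in place of methyl on an aromatic carbon. This change gave a 1.2-fold higher number from compound 1 to compound 2 (0.09 log units; within the scatter), a step that is within the scatter.

Compound 4 `COc1ccc(C(=O)Nc2cccc(-c3nc4c(c(=O)n(C)c(=O)n4C)n3C)c2)cc1` is not yet measured in this assay. It differs from compound 3 by methoxy in place of methyl on an aromatic carbon, the same change made from compound 1 to compound 2 at the same place. Because the earlier step was a 1.2-fold higher number from compound 1 to compound 2 (0.09 log units; within the scatter), the step expected here is a 1.2-fold higher number from compound 3 to compound 4 (0.08 log units; within the scatter). Compound 4 is therefore estimated at 20000 nM in this assay, with an expected range from 9000 nM to 45000 nM.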

Compound 4, half-maximal inhibitory concentration: 17800 nM
For compound 4 the middle estimate is 1.1-fold (0.05 log units) above the measured one; the measured number falls inside the stated range.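

In this assay, methoxy in place of methyl on an aromatic carbon gave a 1.1-fold higher number from compound 3 to compound 4 (0.03 log units; within the scatter) and matched the earlier step on the other core: the same change on two cores in this assay, a 1.2-fold higher number (0.09 log units; within the scatter) from compound 1 to compound 2 and a 1.1-fold higher number (0.03 log units; within the scatter) from compound 3 to compound 4, 1.2-fold (0.06 log units) apart, within the scatter of two such steps

Within these two cores, the change therefore behaves alike, with neither step distinguishable from scatter. This shows no measurable effect of the swap on either core, and it does not show that the agreement would hold on other cores or for a change with a larger step.

Open, going by these compounds, is whether an amine, a carboxylic acid or a longer chain in place of the methoxy would move the number beyond the scatter. Also open, on these data alone, is how the two cores compare when only the core differs.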